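Swapping an Amide for an Ester on Compound 1

This account rests on a few compounds, and the source may have more. Where it says the series, first, only, none or still open, it means among the compounds named here.

Measured so far:
Compound 1, `Cn1ncc2cc(-c3cnccc3/C=C/C(=O)N3CCOCC3)ccc21`: 356 nM
Compound 2, `Cn1ncc2ccc(-c3cnccc3/C=C/C(=O)N3CCOCC3)cc21`: 853 nM
Compound 3, `COC(=O)CCc1ccncc1-c1ccc2ccccc2c1`: 259 nM

All three numbers come from an assay on a protein complex for inhibition of CDK8/Cyclin C (Homo sapiens), with a stated time of 1 h; a higher number here means a weaker inhibitor, a lower number a stronger inhibitor. Compound 1 holds the second-highest number of the three. Its nearest neighbour is compound 3, whose value sits within the usual scatter of compound 1, so the two cannot be told apart. Compound 2 lies further off, beyond the scatter, with the higher number of the pair. No two of these compounds differ in only one place, so no single step between measured compounds can be read off.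

Compound 4, `CCOC(=O)/C=C/c1ccncc1-c1ccc2c(cnn2C)c1`, has not yet been measured in this assay. Compared with compound 1 it differs in one place: ethoxy in place of morpholin-4-yl on a carbonyl carbon. Compound 3 also carries an ester rather than an amide and sits close to compound 1 in this assay, although its core is different, so it offers only a loose hint.

Among the compounds with values here, with no directly comparable step available, the expectation for compound 4 is a step of no size beyond the scatter, leaning if anything toward a slightly higher number. The expected step is a 1.4-fold higher number from compound 1 to compound 4 (0.15 log units; within the scatter). Compound 4 is expected to give 500 nM, with a likely range from 150 nM to 1700 nM.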

Compound 4, half-maximal inhibitory concentration: 102 nM
Compound 4: middle estimate off by 4.9-fold (0.69 log units), on the high side; the measured number lies below the stated range.
By their numbers in this assay, from the lowest: compound 4; then compounds 3 and 1 (each within the scatter of the next); then compound 2.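

In this assay, ethoxy in place of morpholin-4-yl on the carbonyl carbon gives a 3.5-fold lower number from compound 1 to compound 4 (0.54 log units; beyond the scatter), so what sits on this carbonyl carbon does affect the result. The change turns the amide into an ester and replaces a group of six heavy atoms, including a ring, with a chainlike group of three, and the compound becomes a stronger inhibitor rather than a weaker one. On the core of compound 1, then, the morpholine ring is not required for inhibition in this assay, and nothing shown explains whether the gain comes from losing the ring, from gaining the ester or from something else.

This is a single step, so it cannot show whether other groups on the same carbonyl carbon would follow the same trend, such as methoxy, a free carboxylic acid or a small open-chain dimethylamino amide. It also leaves open whether the same swap would give a similar step on the core of compound 2, where the morpholine amide is the only form shown.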